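Azetidine ureas on the shared core: removing the methoxy

This account rests on a few compounds, and the source may have more. Where it says the series, first, only, none or still open, it means among the compounds named here.

Working notes on the series. Compound 1 `COC1CCN(C(=O)N2CC(c3nc(-c4cccc(Cl)c4)no3)C2)CC1` gives, in an assay on HEK293 cells for negative allosteric modulation of metabotropic glutamate receptor 5 (Homo sapiens), read by FLIPR (a lower number here means a stronger inhibitor, a higher number a weaker inhibitor), a reading of > 10000 nM, which is a limit of the assay and not a number. Compound 2 `O=C(c1ccc(F)cc1)N1CC(c2nc(-c3cccc(F)c3)no2)C1` likewise shows only a limit, > 10000 nM, in this assay. Within the data shown here, compound 3 `O=S(=O)(c1ccc(F)cc1)N1CC(c2nc(-c3cccc(Cl)c3)no2)C1` is the single member with a numerical reading, 130 nM in this assay. Two of the three readings thus sit at the limit (the limit of > 10000 nM in this assay, at which 2 of the 3 values shown sit), and compound 1 is among them.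

The step to compound 4 `O=C(N1CCCCC1)N1CC(c2nc(-c3cccc(Cl)c3)no2)C1` is small: hydrogen in place of methoxy on a saturated ring carbon. No measured pair in this set differs in one place, so the size of such a step is not shown; the urea in compound 1 remains as it is, and only the methoxy is lost.

Given that compound 1 stands at the limit, compound 4 is expected to remain near the limit as well, with an estimated step that the limit leaves unreadable from compound 1 to compound 4 of no meaning beyond the scatter. The estimate for compound 4 in this assay is 15000 nM, ranging from 3000 nM to 60000 nM.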

Compound 4, half-maximal inhibitory concentration: > 10000 nM
Compound 4 gave a limit, no number; the forecaster's own chance of this, stated with the estimate: 75%; the middle value is on the limit's open side.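

Among these compounds, compound 1 and compound 4 both stand at a limit in this assay, and no step between them can be read. The compounds shown leave open how far hydrogen in place of methoxy shifts inhibition, and whether a urea on the shared core can give a numerical reading.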